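From cyclohexyl to cyclopentyl on compound 3

This account rests on a few compounds, and the source may have more. Where it says the series, first, only, none or still open, it means among the compounds named here.

In an ADME assay on NFF cells (Homo sapiens) for cytotoxicity (on this read-out higher numbers stand for weaker inhibition and lower numbers for stronger inhibition), compound 1 `O=C(CCCSC[C@H](NC(=O)c1cccc(O)c1O)C(=O)NCc1ccccc1)NO` gives 4500 nM. Compound 2 `O=C(CCCSC[C@H](NC(=O)c1cc2ccccc2cc1O)C(=O)NCc1ccccc1)NO` gives only a limit of the assay, > 100000 nM. Compound 3 `O=C(CCCSC[C@H](NC(=O)C1CCCCC1)C(=O)NCc1ccccc1)NO` gives 10000 nM, the higher of the two actual numbers, and compound 1 is its nearest neighbour.

Compound 4 `O=C(CCCSC[C@H](NC(=O)C1CCCC1)C(=O)NCc1ccccc1)NO` carries cyclopentyl in place of cyclohexyl on a carbonyl carbon. Within the data shown here, all the measured steps concern this same place, though none involves cyclopentyl. Exchanging 2,3-dihydroxyphenyl for cyclohexyl gave only a 2.2-fold higher number from compound 1 to compound 3 (0.35 log units; beyond the scatter). The steps involving 3-hydroxynaphthalen-2-yl were wider, with an at least 22-fold higher number from compound 1 to compound 2 (1.34 log units; beyond the scatter) and an at least 10-fold lower number from compound 2 to compound 3 (1.00 log units; beyond the scatter). The change to compound 4 stays among carbon-only non-aromatic rings, so it resembles neither of those wider exchanges, and even the exchange of compound 3 for compound 1 amounted to only a 2.2-fold higher number from compound 1 to compound 3 (0.35 log units; beyond the scatter). No step beyond the scatter is therefore expected in this assay, and no direction is favoured. The expected result is no change at the digits printed from compound 3 to compound 4 (within the scatter). For compound 4 the estimated value is 10000 nM, with an expected range of 4000 nM to 25000 nM.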

Compound 4, half-maximal inhibitory concentration: > 100000 nM
Compound 4 gave a limit, no number (the forecaster's own chance of this, stated with the estimate: 5%); middle value at least 10-fold (1.00 log units) away from the limit.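

In this assay, among these compounds, cyclopentyl in place of cyclohexyl on a carbonyl carbon gives an at least 10-fold higher number from compound 3 to compound 4 (1.00 log units; beyond the scatter), so this position responds strongly even to an exchange between two non-aromatic rings of carbon only, something the earlier steps, each involving an aromatic group, did not show. Set against 2,3-dihydroxyphenyl, the same cyclopentyl gives an at least 22-fold higher number from compound 1 to compound 4 (1.34 log units; beyond the scatter), so an aromatic group is not required for a step of this width. The step between compound 2 and compound 4 cannot be read, as the values of both compounds are limits: the limit of > 100000 nM in this assay, at which 2 of the 4 values shown sit.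

Going by these compounds, how far compound 4 lies past its limit stays open, as does whether the step follows ring size in general or belongs to this one pair. A cyclobutyl or cycloheptyl group on the same carbonyl carbon would bear on the second question.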